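Swapping chloro for methyl on the triazole aryl group

A few compounds are considered here, and "the series" means these few. Any claim that something is new, unique, unknown or untested is made for them only; others in the source may bear on it.

Three compounds share one core and differ only in the aryl group attached to the triazole nitrogen. Compound 1 `COc1ccc(-n2nncc2CN2C(=O)C3(C(C#N)=C(N)Oc4c(N)cc5nc6ccccc6nc5c43)c3ccccc32)cc1` carries a 4-methoxyphenyl group. In a functional assay on A549 cells (Homo sapiens) for antiproliferative activity, read by MTT assay, with a stated time of 48 h (on this read-out higher numbers stand for weaker inhibition and lower numbers for stronger inhibition), compound 1 gives > 50000 nM, which is a limit of the assay rather than a number. Compound 2 `CCOc1ccccc1-n1nncc1CN1C(=O)C2(C(C#N)=C(N)Oc3c(N)cc4nc5ccccc5nc4c32)c2ccccc21` carries a 2-ethoxyphenyl group. In this assay compound 2 gives > 50000 nM, again a limit. Compound 3 `N#CC1=C(N)Oc2c(N)cc3nc4ccccc4nc3c2C12C(=O)N(Cc1cnnn1-c1cc(Cl)ccc1Cl)c1ccccc12` carries a 2,5-dichlorophenyl group and is the only one of the three with a number: in this assay compound 3 gives 10900 nM. The two limits are the limit of > 50000 nM in this assay, at which 2 of the 3 values shown sit, so the step that the two limits leave unreadable from compound 1 to compound 2 cannot be read. The steps of an at least 4.5-fold lower number from compound 1 to compound 3 (0.66 log units; beyond the scatter) and an at least 4.5-fold lower number from compound 2 to compound 3 (0.66 log units; beyond the scatter) both run the same way, towards compound 3.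

Compound 4 `Cc1ccc(Cl)cc1-n1nncc1CN1C(=O)C2(C(C#N)=C(N)Oc3c(N)cc4nc5ccccc5nc4c32)c2ccccc21` differs from compound 3 by methyl in place of chloro on an aromatic carbon. Going by the values given here, none of the measured steps touches this exchange, since each of them swaps the whole aryl group. One therefore expects no step beyond the scatter, a 1.3-fold higher number from compound 3 to compound 4 (0.11 log units; within the scatter). For compound 4 in this assay the estimate is 14000 nM, with a range from 4500 nM to 45000 nM.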

Compound 4, half-maximal inhibitory concentration: > 50000 nM
Compound 4 gave a limit, no number (the forecaster's own chance of this, stated with the estimate: 25%); middle value at least 3.5-fold (0.55 log units) away from the limit.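

In this assay, exchanging a single chloro for methyl, on an aromatic carbon ortho to a large group and para to a chloro group, gives an at least 4.5-fold higher number from compound 3 to compound 4 (0.66 log units; beyond the scatter). The earlier readable steps replaced the whole aryl group, so they could not tie the number of compound 3 to any one place; this step changes one heavy atom, adds no ring and alters no hydrogen-bond donor or acceptor count, and it is enough to lose that number. Compound 4 therefore joins compound 1 and compound 2 at a limit rather than a number, and the steps among these three cannot be read, as all of them sit at the same limit: the limit of > 50000 nM in this assay, at which 3 of the 4 values shown sit.

The compounds shown leave open whether another group at this place, such as fluoro, bromo or methoxy, would keep the activity of compound 3 or improve on it. They also leave open what the chloro para to this place contributes, as every step shown that touches it replaces the whole aryl group.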